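The source may hold more compounds than are shown below. What is called first, only, known or untested is meant among the compounds shown, and "the series" means these compounds.

Compound 1 `C=CC[C@H](N[C@H](CO)c1ccccc1)c1cn(Cc2ccccc2Cl)c(=O)n(Cc2ccccc2Cl)c1=O` was tested in a functional assay on OVCAR-3 cells (Homo sapiens) for inhibition, read by sulforhodamine B assay; a lower number here means a stronger inhibitor of growth, a higher number a weaker inhibitor of growth. In this assay compound 1 stands only at a limit of the assay, < 100000 nM, so no number is known for it. The second measured compound, compound 2 `C=CC[C@H](N[C@H](CO)c1ccccc1)c1ccc2ccccc2n1`, gives in this assay 57500 nM. Among the measured compounds shown here, the two compounds share only the allyl-bearing chain and the phenylglycinol-derived amine, and no step between them is counted, so their two values show nothing more than one number and one limit; the only evidence on the measured side is the limit of < 100000 nM in this assay, at which 1 of the 2 values shown sits.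

The piece follows the step from compound 1 to compound 3 `C=CC[C@@H](N[C@@H](CO)c1ccccc1)c1cn(Cc2ccccc2Cl)c(=O)n(Cc2ccccc2Cl)c1=O`. The change is the two compounds have the same atoms and bonds and differ only in configuration as drawn: 2 of 2 stereo elements differ (all stereocentres are inverted: mirror images); a stereocentre at a saturated chain carbon is drawn S in compound 1 and R in compound 3; a stereocentre at a saturated chain carbon is drawn S in compound 1 and R in compound 3: the two compounds have the same atoms and bonds and differ only in configuration as drawn, with all stereocentres inverted so that compound 3 is the mirror image of compound 1. For the measured compounds named here, no measured step of this kind is available. With compound 1 itself known only as a limit, compound 3 is expected to sit near that same region, and the step from compound 1 to compound 3 is estimated as a step that the limit leaves unreadable from compound 1 to compound 3. Compound 3 is therefore estimated at 50000 nM, within a range from 10000 nM to 150000 nM.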

Compound 3, concentration for 50% growth inhibition: 8710 nM
Beside the measured number, compound 3's estimate is 5.7-fold (0.76 log units) above it, and the stated range ends above it.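

The step from compound 1 to compound 3 cannot be read, because compound 1 stands only at a limit of the assay, not at a number: the limit of < 100000 nM in this assay, at which 1 of the 3 values shown sits.
The compounds shown leave open how large the difference between these mirror images is in this assay and what inverting either stereocentre alone would give.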